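The compounds below may be only part of what the source reports. "The series", "measured", "known", "first", "only" and "open" are said of these compounds alone.

Within the data shown here, in a functional assay on MCF cells (Homo sapiens) for antiproliferative activity, with a stated time of 72 h (a lower number here means a stronger inhibitor, a higher number a weaker inhibitor), compound 2 `OC[C@H]1O[C@@H](n2cnc3c(NCc4cccc(F)c4)ncnc32)[C@H](O)[C@@H]1O`, which carries a 3-fluorophenyl group on the shared core, gives 15300 nM, the only true number so far. Compound 1 `OC[C@H]1O[C@@H](n2cnc3c(NCc4ccccc4F)ncnc32)[C@H](O)[C@@H]1O` reads > 166000 nM, which is a limit of the assay and not a number. Going to compound 3 `OC[C@H]1O[C@@H](n2cnc3c(NCc4ccccc4Cl)ncnc32)[C@H](O)[C@@H]1O` puts 2-chlorophenyl in place of 3-fluorophenyl on a saturated chain carbon bound to a nitrogen on an aromatic ring. Among the measured compounds shown here, one measured step bears on this: an at least 10-fold lower number from compound 1 to compound 2 (1.03 log units; beyond the scatter). Read backwards, that step suggests that a 2-chlorophenyl group, like the 2-fluorophenyl of compound 1, should raise the number, though a single step is thin support and chlorine is not fluorine. Weaker inhibition is therefore expected, beyond the scatter, as the estimated 3.9-fold higher number from compound 2 to compound 3 (0.59 log units; beyond the scatter). For compound 3 the estimated value is 60000 nM, with an expected range of 18000 nM to 200000 nM.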

Compound 3, half-maximal inhibitory concentration: > 166000 nM
Compound 3: only a limit was reported; the forecaster's own chance of this, stated with the estimate: 45%; middle value at least 2.7-fold (0.44 log units) from the limit.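

In this assay, the change from 3-fluorophenyl to 2-chlorophenyl on this carbon gives an at least 10-fold higher number from compound 2 to compound 3 (1.03 log units; beyond the scatter), so a second group, not only 2-fluorophenyl, now loses the readable activity seen with 3-fluorophenyl. Compound 3 reads > 166000 nM, which is a limit of the assay and not a number. The swap of fluoro for chloro from compound 1 to compound 3 cannot be read, so any difference between these two stays hidden, and the data can only point to the ceiling they share: the limit of > 166000 nM in this assay, at which 2 of the 3 values shown sit.

Among these compounds, compound 2 holds the only true number here, so how far this group can change and still give a readable value remains unknown. On these data alone, what a plain phenyl group, or a longer chain ending in an amine, would give on this carbon also stays open.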